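Working notes: from compound 3 to compound 4

The source may report more compounds than this note shows. Statements on the series, on what has been measured and on what is new or still open speak of the compounds shown alone.

In a functional assay on BaF3 cells (Mus musculus) for antiproliferative activity (a lower number here means that less compound is needed, a higher number that more compound is needed for the effect), compound 3 `CCN1CCN(Cc2ccc(NC(=O)c3ccc(C)c(C#Cc4cnc5[nH]c(C)cc5c4)c3)cc2C(F)(F)F)CC1` gives 1000 nM. This value lies within the scatter of compound 1 `CCN1CCN(Cc2ccc(NC(=O)c3ccc(C)c(C#Cc4cccnc4)c3)cc2C(F)(F)F)CC1` at 1590 nM. Compound 2 `CCN1CCN(Cc2ccc(NC(=O)c3ccc(C)c(C#Cc4cncnc4)c3)cc2C(F)(F)F)CC1` at 2190 nM stands apart from it, with a 2.2-fold lower number from compound 2 to compound 3 (0.34 log units; beyond the scatter).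

The change leading to compound 4 `CCN1CCN(Cc2ccc(NC(=O)c3ccc(C)c(C#Cc4cnc5[nH]cnc5c4)c3)cc2C(F)(F)F)CC1` is a group of 9 heavy atoms (6 carbon, 3 nitrogen; one five-membered aromatic ring with 2 hetero atoms, one six-membered aromatic ring with 1 hetero atom) in place of a group of 10 heavy atoms (8 carbon, 2 nitrogen; one five-membered aromatic ring with 1 hetero atom, one six-membered aromatic ring with 1 hetero atom), on a triple-bonded carbon. Among the compounds with values here, no measured step makes this exact exchange. Within the data shown here, the closest precedent is pyrimidin-5-yl in place of pyridin-3-yl, with a 1.4-fold higher number from compound 1 to compound 2 (0.14 log units; within the scatter), which stays within the scatter. The exchange of the six-membered group in compound 1 for the larger group in compound 3, with a 1.6-fold lower number from compound 1 to compound 3 (0.20 log units; within the scatter), also stays within the scatter. Among the measured compounds shown here, only the step from compound 2 to compound 3 passes it, and only modestly. No step beyond the scatter is expected in this assay, with a slight lean towards a higher number. The expected step is a 1.4-fold higher number from compound 3 to compound 4 (0.15 log units; within the scatter). For compound 4 the estimated value is 1400 nM, with an expected range from 650 nM to 3000 nM.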

Compound 4, half-maximal effective concentration: 60 nM
Beside the measured number, compound 4's estimate is 23-fold (1.37 log units) above it; the whole stated range lies above it.
By their numbers in this assay, from the lowest: compound 4; then compounds 3, 1 and 2 (each within the scatter of the next, the first and the last beyond it).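

In this assay, the group on the triple-bonded carbon can move the number far more than the earlier exchanges suggested, with large steps for the new group against all three earlier groups (a 17-fold lower number from compound 3 to compound 4 (1.22 log units; beyond the scatter); a 27-fold lower number from compound 1 to compound 4 (1.42 log units; beyond the scatter); a 37-fold lower number from compound 2 to compound 4 (1.56 log units; beyond the scatter)). Two aromatic rings in the group are not enough in themselves, as compound 3 also has a five-membered and a six-membered aromatic ring, yet only compound 4 shows a step of this size. No supporting data bear on the origin of this difference.

The exchange from compound 3 to compound 4 alters the carbon and nitrogen counts together, so the compounds shown do not separate these two changes. From the compounds shown here alone, it also remains open whether an amine or a carboxylic acid on the group entering in compound 4 would keep the low number.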